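From tert-butyl to piperazin-1-yl in compound 4

The source may report more compounds than this note shows. Statements on the series, on what has been measured and on what is new or still open speak of the compounds shown alone.

In an ADME assay on NIH3T3 cells (Mus musculus) for cytotoxicity (a lower number here means that less compound is tolerated, a higher number that more compound is tolerated), three compounds have been measured:
Compound 1 `CN(C)CC#Cc1cc2ncnc(Nc3ccc(OCc4cccc(F)c4)c(Cl)c3)c2s1` gives > 50 uM as a limit
Compound 2 `COCC#Cc1cc2ncnc(Nc3ccc(OCc4cccc(F)c4)c(Cl)c3)c2s1` gives > 50 uM as a limit
Compound 3 `CC(C)(C)CC#Cc1cc2c(Nc3ccc(OCc4cccc(F)c4)c(Cl)c3)ncnc2s1` gives > 50 uM as a limit

Compound 3 therefore has no exact number, and the other two compounds offer none to rank it against. Compound 4 `Fc1cccc(COc2ccc(Nc3ncnc4sc(C#CCN5CCNCC5)cc34)cc2Cl)c1` differs from compound 3 by one change: piperazin-1-yl in place of tert-butyl on a saturated chain carbon bound to a triple-bonded carbon. Among the measured compounds shown here, the one measured step at this place is a step that the two limits leave unreadable from compound 1 to compound 2, and it gives no size to carry over. The evidence is simply (the limit of > 50 uM in this assay, at which 3 of the 3 values shown sit), which suggests that changing this group has so far left the result at the limit. Compound 1 carries dimethylamino at this place and gives > 50 uM as a limit. Its core differs from that of compound 3, so this is only a loose guide. a step that the limit leaves unreadable from compound 3 to compound 4 is the expected step in this assay, and nothing beyond the scatter is expected. The estimate for compound 4 is 60 uM with an expected range of 25 uM to 120 uM overall.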

Compound 4, half-maximal toxic concentration: 3.9 uM
Compound 4: the middle estimate sits 15-fold (1.19 log units) above what was measured; measured number below the stated range.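

In this assay this place, the saturated chain carbon bound to a triple-bonded carbon, now gives a readable change, with an at least 12-fold lower number from compound 3 to compound 4 (1.10 log units; beyond the scatter). The group at this place can therefore decide how much compound the cells tolerate, and swapping tert-butyl for piperazin-1-yl moves the result well beyond the usual scatter. Among the compounds shown here, until now, this assay had offered only a limit, and none of the earlier steps could be read: the limit of > 50 uM in this assay, at which 3 of the 4 values shown sit.

This single step changes the ring and the nitrogen atoms together, so it cannot show which of them matters. Piperidin-1-yl or morpholin-4-yl at this place could separate the two, and it also remains open whether piperazin-1-yl would bring the same drop on the core of compound 1.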